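Branching the ester chain of a long-lived ester

This account rests on a few compounds, and the source may have more. Where it says the series, first, only, none or still open, it means among the compounds named here.

Compound 2, `CCCOC(=O)/C=C/c1ccc(NC(=O)C2(NC(=O)c3ccc4c(C5CCCC5)c(-c5ncc(Cl)cn5)n(C)c4c3)CCC2)cc1OCC`, was examined in an ADME assay for pharmacokinetics, in simulated intestinal fluid; on this read-out lower numbers stand for a shorter-lived compound and higher numbers for a longer-lived compound. In this assay compound 2 reaches > 5 h, which is a limit of the assay rather than a measured number. Among the measured compounds shown here, the one measured step leading to it starts from compound 1, `CCOc1cc(NC(=O)C2(NC(=O)c3ccc4c(C5CCCC5)c(-c5ncc(Cl)cn5)n(C)c4c3)CCC2)ccc1/C=C/C(=O)N[C@@H](CC(=O)O)C(N)=O`, which in this assay gives 0.0667 h. That step, an at least 74-fold higher number from compound 1 to compound 2 (1.87 log units; beyond the scatter), was large and sits at the assay limit (the limit of > 5 h in this assay, at which 1 of the 2 values shown sits). Compound 3, `CCOc1cc(NC(=O)C2(NC(=O)c3ccc4c(C5CCCC5)c(-c5ncc(Cl)cn5)n(C)c4c3)CCC2)ccc1/C=C/C(=O)OCC(C)C`, differs from compound 2 by methyl in place of hydrogen on a saturated chain carbon bound to two saturated chain carbons. For the measured compounds named here, no measured step concerns such a small branching of the ester chain; the only known step exchanged the whole group on the carbonyl carbon. The expected step is therefore small, a step that the limit leaves unreadable from compound 2 to compound 3, with the number again likely to come back as a limit. Compound 3 is estimated at 8 h, in a range from 3 h to 30 h.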

Compound 3, half-life: > 5 h
Compound 3: no number, only a limit; the forecaster's own chance of this, stated with the estimate: 75%; the middle value lies beyond the limit too.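

Isobutoxy on the carbonyl carbon behaves like propoxy in one respect: replacing the (1-carbamoyl-2-carboxyethyl)amino group with it gives an at least 74-fold higher number from compound 1 to compound 3 (1.87 log units; beyond the scatter), so the large step seen with compound 2 is not tied to a single ester chain. In this assay compound 3 gives > 5 h, which is a limit of the assay and not a number. The step from compound 2 to compound 3 cannot be read, so the added methyl may or may not have changed the half-life: the limit of > 5 h in this assay, at which 2 of the 3 values shown sit.

From the compounds shown here alone, how far either ester lies beyond the limit stays unknown, so the propyl and isobutyl chains cannot be ranked. Going by these compounds, it also remains open whether a longer chain or an amine on this carbonyl carbon would reach the same limit.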